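Benzyl to Methyl on a Scaffold at the Limit

This account rests on a few compounds, and the source may have more. Where it says the series, first, only, none or still open, it means among the compounds named here.

Measured compounds:
compound 1 `CC(C)C[C@]1(O)NC(=O)[C@]2(OC(Cc3ccccc3)=CC2=O)[C@H]1O`: > 100000 nM
compound 2 `CC(C)CC(=O)C1Oc2cc(Cc3ccccc3)[nH]c(=O)c2O1`: > 100000 nM
compound 3 `CC1=CC(=O)[C@@]2(O[C@H]2C(=O)CC(C)C)C(=O)N1`: "not determined" (no result reported)

In a functional assay on HCT-116 cells (Homo sapiens) for cytotoxicity, read by WST assay, with a stated time of 48 h (on this read-out lower numbers stand for stronger inhibition and higher numbers for weaker inhibition), compound 1 gives > 100000 nM, which is a limit of the assay and not a number. Compound 2 likewise gives > 100000 nM, again only a limit. For compound 3 no result was reported. Two of the three entries thus sit at the limit of > 100000 nM in this assay, at which 2 of the 3 values shown sit, and compound 1 stands at that limit with no measured neighbour that is active. Compound 4 `CC1=CC(=O)[C@]2(O1)C(=O)N[C@@](O)(CC(C)C)[C@@H]2O` differs from compound 1 by hydrogen in place of phenyl on a saturated chain carbon bound to a double-bonded ring carbon. Within the data shown here, with no measured step between any two compounds to lean on, the expected step from compound 1 to compound 4 in this assay is none beyond the scatter, a number no higher from compound 1 to compound 4 (the limit leaves the size open). Compound 4 is therefore expected at 100000 nM, within 30000 nM to 300000 nM, most likely reported once more only as a limit.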

Compound 4, half-maximal inhibitory concentration: > 100000 nM
Compound 4 gave a limit, no number (the forecaster's own chance of this, stated with the estimate: 80%); the middle value lies on the limit itself.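

No step can be read from compound 1 to compound 4, because both values are limits and not numbers: the limit of > 100000 nM in this assay, at which 3 of the 4 values shown sit.

The compounds shown leave open whether swapping benzyl for methyl changes anything in this assay, and how far beyond the limit either compound lies.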